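The compounds below may be only part of what the source reports. "The series", "measured", "known", "first", "only" and "open" are said of these compounds alone.

The two measured compounds:
Compound 1, `COc1cc(C)cc(-c2c(-c3ccnc(-c4ccc(C(C)=O)cc4)c3)cnn2CC#N)c1`, gives -67% in a functional assay on COLO 205 cells (Homo sapiens) for cytotoxicity, read by sulforhodamine B assay, with a stated time of 48 h, tested at 10 uM; a higher number here means a weaker effect of the compound at the concentration tested, a lower number a stronger effect.
Compound 2, `COc1cc(C)cc(-c2nn(CC#N)cc2-c2ccc(-c3cccc(C(C)=O)c3)nc2)c1`, gives -62% in this assay.

Compound 1 holds the lowest of the two numbers in this assay. Its nearest neighbour is compound 2, whose number lies only slightly higher, a gap that sits within the usual scatter of this measurement, so the two cannot be ordered against each other.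

The step under consideration leads from compound 1 to compound 3, `COc1cc(C)cc(-c2c(-c3ccnc(-c4ccc(N(C)C)cc4)c3)cnn2CC#N)c1`, which has not yet been measured. The change is dimethylamino in place of acetyl on an aromatic carbon. For the measured compounds named here, no measured pair in this set shows this change, so no measured step can be called on for it. In this assay a modest step is expected, most likely toward a higher number, but of a size that may not clearly exceed the scatter seen between compound 1 and compound 2. Compound 3 is therefore expected to give -50%, with a plausible range from -80% to -10%. This corresponds to an expected step of a number 17 percentage points higher from compound 1 to compound 3 (beyond the scatter).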

Compound 3, a percentage reported as activity, at one concentration (the size of the read-out at that concentration, not a potency): 4%
Beside the measured number, compound 3's estimate is 54 percentage points below it; the whole stated range lies below it.
By their numbers in this assay, from the lowest: compounds 1 and 2 (each within the scatter of the next); then compound 3.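

In this assay, the exchange of acetyl for dimethylamino, on an aromatic carbon para to a large group, gives a number 71 percentage points higher from compound 1 to compound 3 (beyond the scatter), which shows that the read-out depends strongly on the group at this position, something compound 1 and compound 2 could not show because they differ in more than one place. The two groups match in heavy-atom number, hydrogen-bond donors, hydrogen-bond acceptors and net charge, so these counts do not separate them, although the read-out moves from a negative number for compound 1 to a positive one for compound 3 at 4%. Nothing available explains why this single exchange has so large an effect.

With only acetyl and dimethylamino shown at this position, it remains open whether other groups, such as a primary amine, a methoxy group, a carboxylic acid or a longer ketone chain, would fall nearer compound 1 or nearer compound 3. Going by these compounds, it also remains open whether dimethylamino in place of acetyl would produce a similar step on the core of compound 2.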